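Replacing the propoxycarbonyl group of compound 2

This account rests on a few compounds, and the source may have more. Where it says the series, first, only, none or still open, it means among the compounds named here.

In a functional assay on KBVIN cells (Homo sapiens) for cytotoxicity, read by MTT assay, with a stated time of 72 h (on this read-out higher numbers stand for an effect only at larger amounts of compound and lower numbers for an effect already at smaller amounts), compound 1 (`CCc1cccc2c(OC)c(-c3occ(C)c3C(=O)OC)ccc12`) gives 1.3 ug/mL. Compound 2 (`CCCOC(=O)c1c(C)coc1-c1ccc2c(CC)cccc2c1OC`) gives > 10 ug/mL, which is a limit and not a number, and its standing rests on (the limit of > 10 ug/mL in this assay, at which 1 of the 2 values shown sits).

Compound 3 (`CCc1cccc2c(OC)c(-c3occ(C)c3C(=S)OC)ccc12`) is not yet measured. The change is a group of 4 heavy atoms (2 carbon, 1 oxygen, 1 sulfur; no ring) in place of a group of 6 heavy atoms (4 carbon, 2 oxygen; no ring), on an aromatic carbon, on an aromatic carbon of a five-membered aromatic ring with 1 oxygen.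

Among the measured compounds shown here, the one measured step bearing on this is an at least 7.6-fold higher number from compound 1 to compound 2 (0.88 log units; beyond the scatter), beyond the scatter. For the measured compounds named here, compound 3 lacks that ethyl, as compound 1 does, but carries sulfur where compound 1 has the carbonyl oxygen, and no measured step covers that exchange. A return of similar size is therefore expected, with less certainty. The expected change is an at least 4.0-fold lower number from compound 2 to compound 3 (0.60 log units; beyond the scatter) in this assay, towards a lower number. Compound 3 is estimated at 2.5 ug/mL, with an expected range of 0.7 ug/mL to 9 ug/mL.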

Compound 3, concentration for half-maximal effect: 5.1 ug/mL
Compound 3: middle estimate off by 2.0-fold (0.31 log units), on the low side; measured number inside the range.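

Exchanging the carbonyl oxygen for sulfur on this aromatic carbon gives a 3.9-fold higher number from compound 1 to compound 3 (0.59 log units; beyond the scatter) in this assay, so the position responds to a single atom within the group and not only to the chain carried on the oxygen. Both changes shown from the group of compound 1 raise the number, and none of the compounds shown goes against this. Against the propoxycarbonyl group, the comparison gives only an at least 1.9-fold lower number from compound 2 to compound 3 (0.29 log units; that floor lies within the scatter), which is a floor set by a limit and not a measured difference: the limit of > 10 ug/mL in this assay, at which 1 of the 3 values shown sits.

Going by these compounds, it remains open whether an amide or a carboxylic acid on this carbon would match or lower the number of compound 1. On these data alone, it also remains open whether an ethyl ester, a chain of intermediate length, would fall nearer compound 1 or compound 2.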